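The source may report more compounds than this note shows. Statements on the series, on what has been measured and on what is new or still open speak of the compounds shown alone.

Measured so far:
- Compound 1 `CCN(CC)CCC/N=C(/N=c1\ccn(CCCN(CC)CC)c2cc(Cl)ccc12)c1cccnc1`: > 1 h
- Compound 2 `CCN(CC)CCCCCN/C(C)=N\c1ccnc2cc(Cl)ccc12`: 0.933 h
- Compound 3 `C/C(=N/c1ccnc2cc(Cl)ccc12)NC1CCN(Cc2ccccc2)CC1`: > 1 h

All three compounds were tested in an ADME assay (liver) for metabolic stability, with Liver microsome (Homo sapiens) as the target, read by LC-MS, using microsomes, tested at 1 uM; a lower number here means that the compound disappears faster, a higher number that the compound lasts longer. Compound 1 gives > 1 h, which is a limit of the assay and not a number. Compound 3 gives > 1 h, which is likewise a limit. The set therefore shows (the limit of > 1 h in this assay, at which 2 of the 3 values shown sit). Compound 2, at 0.933 h, is the only one of the three with an actual number.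

Compound 4 `CCN(CC)CCN/C(C)=N\c1ccnc2cc(Cl)ccc12` has not yet been measured. It differs from compound 2 in one place: diethylamino in place of 3-(diethylamino)propyl on a saturated chain carbon, two bonds along the chain from an amine nitrogen. Diethylamino stands in place of 3-(diethylamino)propyl, on a saturated chain carbon, two bonds along the chain from an amine nitrogen. For the measured compounds named here, no measured pair in the set isolates a change of this kind, so no step beyond the usual scatter is expected in this assay, with compound 2 at 0.933 h as the only anchor. The expected step of a 1.2-fold higher number from compound 2 to compound 4 (0.07 log units; within the scatter) is an estimate that stays within that scatter. Compound 4 is estimated at 1.1 h, with an expected range from 0.6 h to 2 h.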

Compound 4, half-life: 0.433 h
Beside the measured number, compound 4's estimate is 2.5-fold (0.40 log units) above it; measured number outside the range, below it.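

Setting diethylamino in place of 3-(diethylamino)propyl on a saturated chain carbon, two bonds along the chain from an amine nitrogen, gives a 2.2-fold lower number from compound 2 to compound 4 (0.33 log units; beyond the scatter) in this assay. For the compounds shown here, this is the first pair in the set that isolates a single change, and it shows that the read-out responds to the group at this place, modestly but beyond the usual scatter. Compound 1 and compound 3 differ from compound 4 in more than one place and add no second pair, and most of the values shown are limits and not numbers: the limit of > 1 h in this assay, at which 2 of the 4 values shown sit.

Going by these compounds, with a single pair, it stays open whether the number follows the length of the chain at all or would shift further with a longer chain. On these data alone, it also stays open whether a ring amine such as piperidine or morpholine in place of the diethylamino end would move the number in the same direction.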